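One oxygen out, three atoms in, on the amide chain

A few compounds are considered here, and "the series" means these few. Any claim that something is new, unique, unknown or untested is made for them only; others in the source may bear on it.

Measured compounds:
- compound 1, `C/C=C/C(=O)N(Cc1ccc(OC)c(N)c1)c1cc(OC)c(OC)c(OC)c1`: 150 nM
- compound 2, `COc1cc(NCc2ccc(Br)cc2)cc(OC)c1OC`: > 80000 nM
- compound 3, `COc1ccc(CN(C(=O)CO)c2cc(OC)c(OC)c(OC)c2)cc1O`: 160 nM

The read-out throughout is a functional assay on MGC-803 cells (Homo sapiens) for inhibition, read by MTT assay, with a stated time of 48 h; on this read-out lower numbers stand for stronger inhibition and higher numbers for weaker inhibition. Compound 3 gives 160 nM. Of the two real numbers in this set, compound 3 has the higher one, but its nearest neighbour is compound 1 with 150 nM, and the gap between the two lies within the usual scatter, so the two cannot be told apart. For compound 2 only a limit is reported, (the limit of > 80000 nM in this assay, at which 1 of the 3 values shown sits), not a number.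

Compound 4, `COc1ccc(CN(C(=O)C[Se]C#N)c2cc(OC)c(OC)c(OC)c2)cc1O`, is not yet measured. It differs from compound 3 in one place: a group of 3 heavy atoms (1 carbon, 1 nitrogen, 1 selenium; no ring) in place of one oxygen atom, on a saturated chain carbon bound to a carbonyl carbon. The rest of the molecule, including the shared core of compound 3 and its amide linkage, stays unchanged.

Among the compounds with values here, no step between measured compounds is available to judge this exchange, so the direction is open. The expectation is that the step from compound 3 to compound 4 stays within the scatter, a 1.3-fold higher number from compound 3 to compound 4 (0.10 log units; within the scatter), with the chance of a moderate move either way. Compound 4 is therefore expected to give about 200 nM, in a range from 60 nM to 700 nM.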

Compound 4, half-maximal inhibitory concentration: 270 nM
For compound 4 the middle estimate is 1.4-fold (0.13 log units) below the measured one; measured number inside the range.
By their numbers in this assay, from the lowest: compounds 1, 3 and 4 (each within the scatter of the next). At a limit, above all of these: compound 2.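

Where the hydroxy stood, on a saturated chain carbon bound to a carbonyl carbon, a group of 3 heavy atoms (1 carbon, 1 nitrogen, 1 selenium) brings a 1.7-fold higher number from compound 3 to compound 4 (0.23 log units; within the scatter) in this assay, so the two compounds cannot be told apart. Within the data shown here, this is the first measured exchange at this place, and it shows that the place tolerates more than a hydroxy: a larger group with a triple bond and no hydrogen-bond donor still gives a number that cannot be separated from that of the hydroxy compound. No measurement shown here explains why the exchange leaves the result within the scatter.

The exchange replaces the whole group at once, so the compounds shown cannot separate any contribution of the selenium from that of the nitrile. As far as these compounds go, it also remains open whether the same tolerance extends to other groups at this place, such as an amine, a carboxylic acid, a longer chain, or a group with sulfur in place of the selenium.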